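Phenyl for Furan on a Porcupine Inhibitor

The source may hold more compounds than are shown below. What is called first, only, known or untested is meant among the compounds shown, and "the series" means these compounds.

Measured compounds:
compound 1 `COc1ccccc1-n1nc(C(=O)NCC(=O)Nc2nc3ccccc3s2)c2ccccc2c1=O` – 10000 nM
compound 2 `O=C(CSc1nc2c(c(=O)n1-c1ccccc1)SCC2)Nc1ncc(-c2ccco2)cn1` – 3.5 nM

In an assay on L cells for inhibition of Protein-serine O-palmitoleoyltransferase porcupine (Mus musculus), read by reporter gene assay, with a stated time of 24 h (on this read-out higher numbers stand for an effect only at larger amounts of compound and lower numbers for an effect already at smaller amounts), compound 2 gives 3.5 nM, the lower of the two numbers, while compound 1 gives 10000 nM, a gap far beyond the scatter. Compound 3 `O=C(CSc1nc2c(c(=O)n1-c1ccccc1)SCC2)Nc1ncc(-c2ccccc2)cn1` differs from compound 2 by phenyl in place of furan-2-yl on an aromatic carbon. Among the compounds with values here, no pair of measured compounds shows this change, so the expectation rests on compound 2 alone. The step of a 1.7-fold higher number from compound 2 to compound 3 (0.23 log units; within the scatter) in this assay is expected to be small, at most a modest loss and possibly none beyond the scatter. Compound 3 is estimated to give 6 nM, with a range from 1.5 nM to 25 nM.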

Compound 3, half-maximal effective concentration: 15 nM
Compound 3: the middle estimate sits 2.5-fold (0.40 log units) below what was measured, within the range that was stated.
By their numbers in this assay, from the lowest: compound 2; then compound 3; then compound 1.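

In this assay, replacing furan-2-yl with phenyl gives a 4.3-fold higher number from compound 2 to compound 3 (0.63 log units; beyond the scatter). Within the data shown here, this is the first reading at this aromatic carbon, and it shows that the position responds to the change of ring, though the step is only modest. The swap changes ring size and removes the furan oxygen, and nothing available bears on what drives the step. The compounds shown leave open whether thiophen-2-yl would track furan-2-yl or phenyl at this carbon. They also leave open how a small non-ring group such as methyl or an amine would read there.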